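The source may report more compounds than this note shows. Statements on the series, on what has been measured and on what is new or still open speak of the compounds shown alone.

Three compounds share one core and differ only at a single aromatic carbon. Compound 1 `Cc1cc(N2CCC(N)CC2)c(S(C)(=O)=O)cc1C(=O)N=C(N)N` carries a methyl group there; in a functional assay for inhibition of sodium/hydrogen exchanger (Oryctolagus cuniculus) (on this read-out higher numbers stand for weaker inhibition and lower numbers for stronger inhibition), compound 1 gives 9.8 nM. Compound 2 `COc1cc(N2CCC(N)CC2)c(S(C)(=O)=O)cc1C(=O)N=C(N)N` carries methoxy instead, and in this assay compound 2 gives 73 nM, so that a 7.4-fold higher number from compound 1 to compound 2 (0.87 log units; beyond the scatter). Compound 3 `CS(=O)(=O)c1cc(C(=O)N=C(N)N)c(Cl)cc1N1CCC(N)CC1` carries chloro; in this assay compound 3 gives 20 nM. Among the three numbers compound 3 stands second highest: a 2.0-fold higher number from compound 1 to compound 3 (0.31 log units; beyond the scatter), while a 3.7-fold lower number from compound 2 to compound 3 (0.56 log units; beyond the scatter).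

Compound 4 `CS(=O)(=O)c1cc(C(=O)N=C(N)N)c(Cl)cc1Nc1ncccn1` keeps the chloro of compound 3 but alters another part of the core: (pyrimidin-2-yl)amino in place of 4-aminopiperidin-1-yl on an aromatic carbon. None of the three measured steps touches this group; all of them exchange methyl, methoxy and chloro on a different aromatic carbon, and the largest of them is a 7.4-fold higher number from compound 1 to compound 2 (0.87 log units; beyond the scatter). The measured data therefore offer no direct guide to the new change, and replacing a non-aromatic ring by an aromatic one is a larger alteration than any examined so far. A modest step toward weaker inhibition, a 3.0-fold higher number from compound 3 to compound 4 (0.48 log units; beyond the scatter), is expected for compound 4. Compound 4 is estimated at 60 nM in this assay, with a range from 10 nM to 400 nM.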

Compound 4, half-maximal inhibitory concentration: 49 nM
For compound 4 the middle estimate is 1.2-fold (0.09 log units) above the measured one; low and high end bracket the measured number.
By their numbers in this assay, from the lowest: compound 1; then compound 3; then compounds 4 and 2 (each within the scatter of the next).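

Among the compounds shown here, the aromatic carbon ortho to a methylsulfonyl group, which none of the earlier steps touched, now has a measured step of its own: in this assay, (pyrimidin-2-yl)amino in place of 4-aminopiperidin-1-yl gives a 2.5-fold higher number from compound 3 to compound 4 (0.39 log units; beyond the scatter), a modest move toward weaker inhibition. The position therefore accepts an exchange of a six-membered non-aromatic ring for a six-membered aromatic ring with two hetero atoms, at the same heavy atom count, and this large structural change costs only a modest step. Nothing available bears on why the number moves as it does, and the step stays unexplained.

On these data alone, this position is seen through a single exchange with chloro held constant, so it remains open whether the step would stay similar with methyl or methoxy on the other aromatic carbon. Also open, as far as these compounds go, is how a plain piperidin-1-yl, a morpholin-4-yl or a phenylamino group would read here, since such groups could separate the removal of the amino group on the piperidine from the change to an aromatic ring.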